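The source may report more compounds than this note shows. Statements on the series, on what has been measured and on what is new or still open speak of the compounds shown alone.

Series notes, inhibition of human topoisomerase 1.

Three compounds share a core carrying two hydroxyphenyl groups and a five-membered heteroaryl group. Compound 1 `Oc1cccc(-c2cc(-c3cccs3)cc(-c3ccccc3O)n2)c1` gives 1.5% in an assay on isolated protein for inhibition of DNA topoisomerase 1 (Homo sapiens), with a stated time of 30 min, tested at 20 uM; on this read-out lower numbers stand for a weaker effect and higher numbers for a stronger effect at the one concentration tested. Compound 2 `Oc1ccc(-c2cc(-c3cccs3)cc(-c3ccccc3O)n2)cc1` gives 2% in this assay. Compound 3 `Oc1ccc(-c2cc(-c3ccco3)cc(-c3cccc(O)c3)n2)cc1` gives 1.5% in this assay. All three readings sit within the usual scatter of one another, so no order among them is claimed.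

The change from compound 1 to compound 2 is 4-hydroxyphenyl in place of 3-hydroxyphenyl on an aromatic carbon; it made a step of a number 0.5 percentage points higher from compound 1 to compound 2 (within the scatter). The same kind of change is now made from compound 3 to compound 4 `Oc1ccc(-c2cc(-c3ccco3)cc(-c3ccc(O)cc3)n2)cc1`, namely (4-hydroxyphenyl in place of 3-hydroxyphenyl on an aromatic carbon). The surroundings of the place are not identical: in the first pair the position is meta to a 2-hydroxyphenyl group and meta to a thiophen-2-yl group, whereas in the second pair it is meta to a 4-hydroxyphenyl group and meta to a furan-2-yl group. How the core of compound 3 differs from the core of compound 1 is not broken down here.

For the measured compounds named here, compound 3 is flat in this assay at 1.5%, and the one earlier instance of the change gave only a number 0.5 percentage points higher from compound 1 to compound 2 (within the scatter), so for compound 4 a step of about a number 0.5 percentage points higher from compound 3 to compound 4 (within the scatter) is expected, resting on that single precedent. Compound 4 is estimated at 2% in this assay, with a range of 0% to 7%.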

Compound 4, a percentage reported as inhibition, at one concentration (the size of the read-out at that concentration, not a potency): 0%
Estimate against measurement, compound 4: 2 percentage points above, and the stated range covers the measured number.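

In this assay, putting 4-hydroxyphenyl in place of 3-hydroxyphenyl on the core of compound 3 gives a number 1.5 percentage points lower from compound 3 to compound 4 (within the scatter), and set beside the earlier instance of the change, the two steps do not differ: the same change on two cores in this assay, a number 0.5 percentage points higher (within the scatter) from compound 1 to compound 2 and a number 1.5 percentage points lower (within the scatter) from compound 3 to compound 4, 2 percentage points apart, within the scatter of two such steps

On these two cores, then, the change carries over in the limited sense that neither step can be told from scatter, whether the neighbouring groups are a 2-hydroxyphenyl and a thiophen-2-yl group or a 4-hydroxyphenyl and a furan-2-yl group. For the compounds shown here, this does not show that the change is neutral in general: there are only two pairs, all four readings lie close to nothing at the one concentration tested, and such readings say little about how the change would behave on a core with a clear effect.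

The two cores differ in more than one place, so the compounds shown leave open what the thiophen-2-yl and furan-2-yl groups each contribute. Also open, on these data alone, is whether an amine or a carboxylic acid in place of a hydroxyl group, or a longer chain in place of the five-membered heteroaryl group, would lift the reading clear of the scatter.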